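The compounds below may be only part of what the source reports. "The series", "measured", "known", "first", "only" and "open" are said of these compounds alone.

Measured compounds:
- compound 1 `CNC(=O)c1cc(Oc2ccc(NC(=O)c3cc4cccnc4n(-c4ccccc4F)c3=O)cc2)ccn1`: 590 nM
- compound 2 `CCCNC(=O)c1cc(Oc2ccc(NC(=O)c3cc4cccnc4n(-c4ccccc4)c3=O)cc2)ccn1`: 110 nM

Both numbers come from a functional assay on NCI-H460 cells (Homo sapiens) for antiproliferative activity, read by MTT assay, with a stated time of 72 h; on this read-out lower numbers stand for stronger inhibition and higher numbers for weaker inhibition. Of the two, compound 2 has the lower number and therefore the stronger inhibition, and compound 1 stands clearly higher, well beyond the usual scatter. The two differ in more than one place, so their gap cannot be tied to a single change.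

Compound 3 `CCCNC(=O)c1cc(Oc2ccc(NC(=O)c3cc4cccnc4n(-c4ccccc4F)c3=O)cc2)ccn1` has not yet been measured. It differs from compound 2 in one place only: fluoro in place of hydrogen on an aromatic carbon, set on an aromatic carbon of a six-membered aromatic ring of carbon only, ortho to a large group. Among the measured compounds shown here, no measured pair shows this change on its own, so the size of its effect is unknown here. The expectation is a step of a 1.6-fold higher number from compound 2 to compound 3 (0.21 log units; within the scatter) that stays within or only slightly beyond the scatter, leaning toward a weaker result. Compound 3 is therefore expected to give about 180 nM, in a range from 60 nM to 600 nM in this assay.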

Compound 3, half-maximal inhibitory concentration: 390 nM
Compound 3: middle estimate off by 2.2-fold (0.34 log units), on the low side; measured number inside the range.
By their numbers in this assay, from the lowest: compound 2; then compounds 3 and 1 (each within the scatter of the next).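

In this assay, the change from phenyl to 2-fluorophenyl, on an aromatic carbon ortho to a large group, can now be read alone: it gives a 3.5-fold higher number from compound 2 to compound 3 (0.55 log units; beyond the scatter) and so weakens inhibition beyond the scatter. With the 2-fluorophenyl kept in place, ethyl in place of hydrogen on the saturated chain carbon bound to the amide-type nitrogen gives a 1.5-fold lower number from compound 1 to compound 3 (0.18 log units; within the scatter) and stays within the scatter, so these two amide chains cannot be told apart here. Nothing available explains the size of the fluoro step.

On these data alone, it remains open whether chloro or methoxy at this ring position would give a similar step. As far as these compounds go, how a butyl chain or a chain ending in an amine on the amide would read also remains open.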